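Removing a Bromo Group: What to Expect for Compound 4

The source may hold more compounds than are shown below. What is called first, only, known or untested is meant among the compounds shown, and "the series" means these compounds.

Compound 1, `C=C1C[C@]23C[C@@]1(O)CC[C@H]2c1ccc(O)c(C)c1[C@@H]3Cn1cc(-c2ccc(Br)cc2)nn1`: > 20000 nM
Compound 2, `C=C1C[C@]23C[C@@]1(O)CC[C@H]2c1ccc(O)c(C)c1[C@@H]3Cn1cc(-c2ccccc2)nn1`: > 20000 nM
Compound 3, `C=C1C[C@]23C[C@@]1(O)CC[C@H]2c1cc(Br)c(O)c(C)c1[C@@H]3Cn1cc(-c2ccc(F)cc2)nn1`: 19200 nM

All three were tested in a functional assay on MCF7 cells (Homo sapiens) for cytotoxicity, read by MTT assay, with a stated time of 4 days; a higher number here means a weaker inhibitor, a lower number a stronger inhibitor. For compound 1 the value > 20000 nM is a limit of the assay, not a number. For compound 2 the value > 20000 nM is likewise a limit. The two differ by hydrogen in place of bromo on an aromatic carbon, and the step that the two limits leave unreadable from compound 1 to compound 2 cannot be sized because of the limit of > 20000 nM in this assay, at which 2 of the 3 values shown sit. Within the data shown here, compound 3 gives the only number in the set, 19200 nM. How the core of compound 3 differs from that of compound 1 is not broken down here.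

Compound 4, `C=C1C[C@]23C[C@@]1(O)CC[C@H]2c1ccc(O)c(C)c1[C@@H]3Cn1cc(-c2ccc(F)cc2)nn1`, is not yet measured. It differs from compound 3 by hydrogen in place of bromo on an aromatic carbon. This is the same kind of change as that from compound 1 to compound 2, but the place differs: in compound 3 the carbon is part of a fused or bridged system of four rings, ortho to a hydroxy group, meta to a fused ring, meta to a methyl group and para to a fused ring, whereas in compound 1 it is para to a large group. Among the measured compounds shown here, since the step that the two limits leave unreadable from compound 1 to compound 2 gives no size, the only anchor is compound 3 at 19200 nM. Compound 4 is expected near 22000 nM, roughly between 9000 nM and 60000 nM. That means an expected step of a 1.1-fold higher number from compound 3 to compound 4 (0.06 log units; within the scatter).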

Compound 4, half-maximal inhibitory concentration: > 20000 nM
Compound 4 was reported as a limit; the forecaster's own chance of this, stated with the estimate: 60%; the middle value lies beyond the limit too.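

In this assay, going by these compounds, hydrogen in place of bromo on the aromatic carbon ortho to a hydroxy group gives an at least 1.0-fold higher number from compound 3 to compound 4 (0.01 log units; that floor lies within the scatter), so only a floor can be read for this change and its true size remains unknown. The steps from compound 1 to compound 2, from compound 2 to compound 4 and from compound 1 to compound 4 cannot be read at all because both ends of each are limits: the limit of > 20000 nM in this assay, at which 3 of the 4 values shown sit. The series therefore shows neither that the change behaves alike at its two places nor that it behaves differently, and it gives no measured size for the change on either core.

On these data alone, it remains open whether an amine or a carboxylic acid in place of the fluoro group of compound 4 would give a number rather than a limit. The same question stands for a longer chain in place of its methyl group.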